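Replacing the pyridine ring: from compound 2 to compound 3

The source may report more compounds than this note shows. Statements on the series, on what has been measured and on what is new or still open speak of the compounds shown alone.

Of the compounds shown here, two sharing a common core have been measured in an assay on CHO cells for displacement of a labelled ligand from adenosine receptor A3 (Homo sapiens), read by scintillation counting, with a stated time of 3 h; on this read-out lower numbers stand for stronger inhibition and higher numbers for weaker inhibition. Compound 1 `Cn1c(-c2ccc(O)cc2)nc2c(NC3CCCC3)ncnc21` carries a 4-hydroxyphenyl group and gives 521 nM in this assay. Compound 2 `Cn1c(-c2cccnc2)nc2c(NC3CCCC3)ncnc21` carries a pyridin-3-yl group in its place and gives 11000 nM. Going by the values given here, the single step between them, a 21-fold higher number from compound 1 to compound 2 (1.32 log units; beyond the scatter), is the only comparison available, and it puts compound 2 at the highest number of the two measured compounds, with compound 1 as its only neighbour.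

Compound 3 `Cc1cccc(-c2nc3c(NC4CCCC4)ncnc3n2C)c1` is not yet measured. It differs from compound 2 by 3-methylphenyl in place of pyridin-3-yl on an aromatic carbon, on an aromatic carbon of a five-membered aromatic ring with 2 nitrogen, between two ring nitrogen atoms. Among the compounds with values here, the one measured step bearing on this change, a 21-fold higher number from compound 1 to compound 2 (1.32 log units; beyond the scatter), was large and ran toward a weaker number when the carbon-only ring gave way to the ring with one hetero atom; returning to a carbon-only ring, though without the hydroxyl, is therefore expected to move the number of compound 3 back down, with a step estimated as a 7.3-fold lower number from compound 2 to compound 3 (0.87 log units; beyond the scatter). Compound 3 is expected to give about 1500 nM in this assay, within a range from 300 nM to 8000 nM.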

Compound 3, inhibition constant: 510 nM
For compound 3 the middle estimate is 2.9-fold (0.47 log units) above the measured one; the measured number falls inside the stated range.
By their numbers in this assay, from the lowest: compounds 3 and 1 (each within the scatter of the next); then compound 2.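

In this assay the change from pyridin-3-yl to 3-methylphenyl on this aromatic carbon gives a 22-fold lower number from compound 2 to compound 3 (1.33 log units; beyond the scatter) and so is about as large as the earlier step in the opposite direction, this time with a carbon-only ring entering rather than leaving. The comparison of the two carbon-only rings reads a 1.0-fold lower number from compound 1 to compound 3 (0.01 log units; within the scatter) and shows that 3-methylphenyl and 4-hydroxyphenyl cannot be told apart at this position, so a hydroxyl on the ring is not required for a number at this level; among the three compounds, the two with a carbon-only ring stand together and compound 2, with its ring nitrogen, stands apart, and none goes against this. Nothing available here accounts for this difference between the rings.

As far as these compounds go, what a plain phenyl ring would give remains open, and with it whether the methyl group of compound 3 and the hydroxyl of compound 1 contribute anything to their numbers at all. Also open, from the compounds shown here alone, is whether a methyl group or a hydroxyl on the pyridin-3-yl ring would bring its number down, and whether the same groups placed differently, as in 4-methylphenyl or 3-hydroxyphenyl, would behave alike.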